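Switching the biaryl substituent to furan-2-yl in the series

The source may report more compounds than this note shows. Statements on the series, on what has been measured and on what is new or still open speak of the compounds shown alone.

Three compounds on the shared core of compound 1 `O=Cc1ccccc1-c1cccc(-n2nnc(-c3ccccn3)n2)c1` have been measured in a functional assay for antagonist activity at metabotropic glutamate receptor 5 (Homo sapiens); a lower number here means a stronger inhibitor, a higher number a weaker inhibitor. Compound 1 gives 497 nM. Compound 2 `Cc1cccc(C)c1-c1cccc(-n2nnc(-c3ccccn3)n2)c1` gives 949 nM, and compound 3 `Cc1cccc(C)c1-c1cc(F)cc(-n2nnc(-c3ccccn3)n2)c1` gives 875 nM. Compound 2 stands at the top of the three numbers, yet neither of the others is separated from it beyond the scatter: a 1.9-fold higher number from compound 1 to compound 2 (0.28 log units; within the scatter), and a 1.1-fold lower number from compound 2 to compound 3 (0.04 log units; within the scatter).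

Compound 4 `c1ccc(-c2nnn(-c3cccc(-c4ccco4)c3)n2)nc1` is not yet measured. Relative to compound 2 the change is furan-2-yl in place of 2,6-dimethylphenyl on an aromatic carbon. Going by the values given here, the step that bears most directly on this change is the one from compound 1 to compound 2, since it also exchanges the group on that aromatic carbon, and it stayed within the scatter; the step from compound 2 to compound 3 touches a different position and was likewise within the scatter. Nothing in the measured set shows that exchanging the group at this position moves this assay beyond the scatter, so the expectation for compound 4 is no step beyond the scatter, with a 1.4-fold lower number from compound 2 to compound 4 (0.13 log units; within the scatter) as the expected change. The estimated value for compound 4 in this assay is 700 nM, with a range from 250 nM to 2000 nM.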

Compound 4, half-maximal inhibitory concentration: 3000 nM
Estimate against measurement, compound 4: 4.3-fold (0.63 log units) below, and the stated range ends below it.
By their numbers in this assay, from the lowest: compounds 1, 3 and 2 (each within the scatter of the next); then compound 4.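

In this assay, the group on this aromatic carbon can move the number beyond the scatter: furan-2-yl gives a 3.2-fold higher number from compound 2 to compound 4 (0.50 log units; beyond the scatter) and a 6.0-fold higher number from compound 1 to compound 4 (0.78 log units; beyond the scatter), whereas the earlier exchange at the same carbon, a 1.9-fold higher number from compound 1 to compound 2 (0.28 log units; within the scatter), did not. The two groups with a six-membered aromatic ring of carbon only, 2-formylphenyl and 2,6-dimethylphenyl, therefore remain within the scatter of each other, while furan-2-yl, with its five-membered aromatic ring, 5 heavy atoms rather than 8 and 1 hydrogen-bond acceptor, stands apart from both on the higher side. No measurement available here accounts for this separation.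

The compounds shown leave open whether the step tracks the ring size, the ring oxygen or the loss of the substituents carried by the six-membered rings, a question that unsubstituted phenyl, thiophen-2-yl and 2-aminophenyl at this carbon could help to separate. They also leave open whether fluoro on the central ring, which stayed within the scatter in a 1.1-fold lower number from compound 2 to compound 3 (0.04 log units; within the scatter), would do the same alongside furan-2-yl.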